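Stereocentre inversion from compound 2 to compound 3

The source may hold more compounds than are shown below. What is called first, only, known or untested is meant among the compounds shown, and "the series" means these compounds.

Of the compounds shown here, two have numbers so far in a physicochemical assay for acid dissociation: compound 1 (`Cc1cc2ncccc2cc1Nc1ncc2c(n1)n(C1CCN(C)CC1)c(=O)n2C`) gives 8.2 and compound 2 (`Cc1cc2ncccc2cc1Nc1ncc2c(n1)n([C@@H]1CCN(C)C1)c(=O)n2C`) gives 8.7. Compound 2 therefore stands highest of the two. Among the measured compounds shown here, the only measured step is a number 0.50 log units higher from compound 1 to compound 2 (beyond the scatter), with 1-methylpyrrolidin-3-yl in place of 1-methylpiperidin-4-yl on an aromatic nitrogen.

Compound 3 (`Cc1cc2ncccc2cc1Nc1ncc2c(n1)n([C@H]1CCN(C)C1)c(=O)n2C`) is still unmeasured. Its difference from compound 2 is the two compounds have the same atoms and bonds and differ only in configuration as drawn: 1 of 1 stereo elements differ; a stereocentre at a saturated ring carbon is drawn R in compound 2 and S in compound 3: a stereocentre at a saturated ring carbon is drawn R in compound 2 and S in compound 3.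

The measured step swaps one group for another, whereas this change leaves the atoms and bonds untouched. For the measured compounds named here, the series holds no measured pair that differs in configuration alone, so the size of a number 0.50 log units higher from compound 1 to compound 2 (beyond the scatter) does not carry over. No step beyond the scatter is expected in this assay, and the expectation starts from compound 2 at 8.7. The estimated change is no change at the digits printed from compound 2 to compound 3 (within the scatter). Compound 3 is expected at 8.7, with an estimated range of 8.4 to 9.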

Compound 3, acid dissociation constant: 8.9
For compound 3 the middle estimate is 0.20 log units below the measured one; measured number inside the range.
By their numbers in this assay, from the lowest: compound 1; then compounds 2 and 3 (each within the scatter of the next).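

In this assay, inverting the stereocentre at the saturated ring carbon gives a number 0.20 log units higher from compound 2 to compound 3 (within the scatter), so this pair shows no effect of drawn configuration beyond the scatter, a reading that is clean on one point: the fact that compounds 2 and 3 differ only in the configuration as drawn

The replacement of 1-methylpiperidin-4-yl by 1-methylpyrrolidin-3-yl on the aromatic nitrogen can now be read for both drawn configurations, as a number 0.50 log units higher from compound 1 to compound 2 (beyond the scatter) and as a number 0.70 log units higher from compound 1 to compound 3 (beyond the scatter). Both steps lie beyond the scatter, so the separation of the 1-methylpyrrolidin-3-yl compounds from the 1-methylpiperidin-4-yl compound does not rest on a single stereoisomer.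

The compounds shown leave open how the number responds to other groups at this position, such as 1-ethylpyrrolidin-3-yl, 1-acetylpyrrolidin-3-yl or 1-methylazetidin-3-yl. They also leave open whether the same lack of a configuration step beyond the scatter would hold for a pair of stereoisomers in another ring, such as the two forms of 1-methylpiperidin-3-yl.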